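The source may hold more compounds than are shown below. What is called first, only, known or untested is meant among the compounds shown, and "the series" means these compounds.

Measured so far in an ADME assay on Vero cells (Chlorocebus sabaeus) for cytotoxicity, read by MTT assay, with a stated time of 72 h; a higher number here means that more compound is tolerated, a lower number that less compound is tolerated:
Compound 1 `CCO/N=C(\C)CN1CCN(c2c(F)cc3c(=O)c(C(=O)O)cn(C4CC4)c3c2OC)CC1C` gives 31.3 ug/mL
Compound 2 `COc1c(N2CCN(C/C(C)=N/NC(N)=O)C(C)C2)c(F)cc2c(=O)c(C(=O)O)cn(C3CC3)c12` gives 500 ug/mL
Compound 3 `COc1c(N2CCN(CC/C(C)=N/O)C(C)C2)c(F)cc2c(=O)c(C(=O)O)cn(C3CC3)c12` gives 44.2 ug/mL

Compound 3 belongs to the lower pair of these values. The gap inside that pair is a 1.4-fold higher number from compound 1 to compound 3 (0.15 log units; within the scatter) and the gap from the highest value is an 11-fold lower number from compound 2 to compound 3 (1.05 log units; beyond the scatter) on the same scale.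

Compound 4 `COc1c(N2CCN(CC/C(C)=N/NC(N)=O)C(C)C2)c(F)cc2c(=O)c(C(=O)O)cn(C3CC3)c12` has not yet been measured. It departs from compound 3 by ureido in place of hydroxy on a double-bonded nitrogen, counted as ureido in place of hydroxy on a double-bonded nitrogen in the comparison of the two structures.

The nearest evidence is a 16-fold higher number from compound 1 to compound 2 (1.20 log units; beyond the scatter) for ureido entering on a double-bonded nitrogen, although there it replaces ethoxy and not hydroxy. Among the compounds with values here, no measured step has hydroxy leaving, and this single ureido step is all the data offer, so its size may not carry over in full. A large rise is still expected in this assay for this change, and it is estimated as a 6.8-fold higher number from compound 3 to compound 4 (0.83 log units; beyond the scatter) in size. For compound 4 the estimated value is 300 ug/mL with 90 ug/mL as its expected lower end and 800 ug/mL as its expected upper end.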

Compound 4, half-maximal cytotoxic concentration: 31.3 ug/mL
Estimate against measurement, compound 4: 9.6-fold (0.98 log units) above, outside the stated range (below it).
By their numbers in this assay, from the lowest: compounds 1, 4 and 3 (each within the scatter of the next); then compound 2.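

In this assay, ureido in place of hydroxy on a double-bonded nitrogen gives a 1.4-fold lower number from compound 3 to compound 4 (0.15 log units; within the scatter) on the longer chain, so there the ureido group does not set compound 4 apart from compound 3, unlike the large rise that ureido in place of ethoxy gave on the shorter chain of compound 1 and compound 2. With ureido present in both compounds, the chain alone separates them in a 16-fold lower number from compound 2 to compound 4 (1.20 log units; beyond the scatter) and the step is large, while no change at the digits printed from compound 1 to compound 4 (within the scatter) places the ureido compound on the longer chain level with the ethoxy compound on the shorter one, so among these compounds the high number belongs to compound 2 only and not to ureido as such. Nothing measured here accounts for this dependence on the chain.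

The compounds shown leave open how hydroxy behaves on the shorter chain and how ethoxy behaves on the longer one, so the two chains cannot yet be compared for those groups. They also leave open whether a still longer chain, or an amine in place of ureido on the double-bonded nitrogen, would follow compound 2 or compound 4.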